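The source may hold more compounds than are shown below. What is called first, only, known or untested is meant among the compounds shown, and "the series" means these compounds.

Within the data shown here, in an ADME assay on Vero cells (Chlorocebus sabaeus) for cytotoxicity, read by resazurin assay, with a stated time of 72 h (on this read-out lower numbers stand for stronger inhibition and higher numbers for weaker inhibition), compound 1 (`CCCCCCNc1c(N(C)CCCN(C)C)c(=O)c1=O`) gives 900000 nM and compound 2 (`CCCCCCCCNc1c(N(C)CCCN(C)C)c(=O)c1=O`) gives 1150000 nM so compound 2 stands within the scatter of its only neighbour. Among the measured compounds shown here, the one measured step bearing on the next change is a 1.3-fold higher number from compound 1 to compound 2 (0.11 log units; within the scatter) and it shows no size beyond the scatter. Compound 3 (`CCCCCCCCCCCCNc1c(N(C)CCCN(C)C)c(=O)c1=O`) differs from compound 2 by butyl in place of hydrogen on a saturated chain carbon, eight bonds along the chain from a nitrogen on an aromatic ring as the change. That butyl is larger than the ethyl of the measured step, and no chain of this length has been measured, so that step is only a weak guide. A modest move towards a lower number is expected in this assay with a wide margin that still allows no change beyond the scatter. The expected step is a 2.9-fold lower number from compound 2 to compound 3 (0.46 log units; beyond the scatter) in this estimate. For compound 3 the estimated value is 400000 nM with an expected range from 50000 nM to 1500000 nM for now.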

Compound 3, half-maximal inhibitory concentration: 128000 nM
Compound 3: the middle estimate sits 3.1-fold (0.49 log units) above what was measured; low and high end bracket the measured number.
By their numbers in this assay, from the lowest: compound 3; then compounds 1 and 2 (each within the scatter of the next).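

In this assay, butyl in place of hydrogen on a saturated chain carbon, eight bonds along the chain from a nitrogen on an aromatic ring, gives a 9.0-fold lower number from compound 2 to compound 3 (0.95 log units; beyond the scatter) and so shows a real change, which the shorter ethyl step six bonds along, a 1.3-fold higher number from compound 1 to compound 2 (0.11 log units; within the scatter), did not. Hexyl in place of hydrogen six bonds along gives a 7.0-fold lower number from compound 1 to compound 3 (0.85 log units; beyond the scatter) and points the same way, so that lengthening the chain lowers the number only once it reaches that of compound 3, among the three compounds shown. Nothing measured accounts for this fall. As far as these compounds go, whether a longer chain lowers the number further, and at what length between compound 2 and compound 3 the fall sets in, stays open. Also open, from the compounds shown here alone, is whether a chain bearing a carboxylic acid or an amine behaves like these plain alkyl chains.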